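Chloro for phenylsulfanyl on the fused core of compound 2

A few compounds are considered here, and "the series" means these few. Any claim that something is new, unique, unknown or untested is made for them only; others in the source may bear on it.

Three compounds have numbers in a functional assay on MCF7 cells (Homo sapiens) for cytotoxicity, read by sulforhodamine B assay, with a stated time of 3 days; a lower number here means a stronger inhibitor, a higher number a weaker inhibitor. Compound 1 `O=c1cc[nH]c(=O)n1C1CN(S(=O)(=O)c2ccccc2[N+](=O)[O-])c2ccccc2CO1` gives 50900 nM, compound 2 `c1ccc(Sc2nc(Sc3ccccc3)c3ncn(C4CNc5ccccc5CO4)c3n2)cc1` gives 9710 nM, and compound 3 `O=S(=O)(c1ccccc1NO)N1CC(n2cnc3c(Cl)nc(Cl)nc32)OCc2ccccc21` gives 1530 nM. Compound 2 holds the second highest number of the three: compound 1 stands nearest with the higher number, compound 3 furthest with the lower number, and both gaps lie beyond the scatter.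

Compound 4 `Clc1nc(Sc2ccccc2)c2ncn(C3CNc4ccccc4CO3)c2n1` has not been measured in this assay. It differs from compound 2 in one place: chloro in place of phenylsulfanyl on an aromatic carbon. For the measured compounds named here, no pair of measured compounds differs in this place alone, so the size of the step cannot be read from measured pairs. Compound 3 carries chloro groups on its fused core and gives 1530 nM, but it differs from compound 2 in other places as well, so it only hints at direction.

Compound 4 is expected to show a step toward a lower number, beyond the scatter but modest. The estimate for compound 4 is 4500 nM, within 1500 nM to 14000 nM. The step of a 2.2-fold lower number from compound 2 to compound 4 (0.33 log units; beyond the scatter) is the expected change.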

Compound 4, half-maximal inhibitory concentration: 13900 nM
For compound 4 the middle estimate is 3.1-fold (0.49 log units) below the measured one; low and high end bracket the measured number.
By their numbers in this assay, from the lowest: compound 3; then compounds 2 and 4 (each within the scatter of the next); then compound 1.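

In this assay, for the compounds shown here, chloro in place of phenylsulfanyl on the aromatic carbon between two ring nitrogen atoms gives a 1.4-fold higher number from compound 2 to compound 4 (0.16 log units; within the scatter), the first reading of this place on its own. A phenylsulfanyl group of 7 heavy atoms carrying a six-membered aromatic ring and a single chlorine atom therefore read alike at this place, so the aromatic ring of the leaving group is not required to keep the number of compound 2 in this assay. Nothing available on the compounds bears on why the two groups read alike.

Still open, from the compounds shown here alone, is whether an amine, a methoxy group or a longer alkylsulfanyl chain at this place would also read alike. Also open, going by these compounds, is the effect of changing the remaining phenylsulfanyl group, which compound 2 and compound 4 share.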